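The source may report more compounds than this note shows. Statements on the series, on what has been measured and on what is new or still open speak of the compounds shown alone.

Of the compounds shown here, three of a shared core have been tested in a functional assay on cells for antagonist activity at C-C chemokine receptor type 4 (Homo sapiens), read by fluorescence and calcium flux, with stated times of 2.5 s and 45 s; a higher number here means a weaker inhibitor, a lower number a stronger inhibitor. Compound 1, `Cc1nn([C@H](C)c2ccc(Cl)cc2Cl)c2nc(N3CC[C@H](N4CCC4)[C@H](C)C3)cnc12`, gives 58 nM in this assay. Compound 3, `C[C@@H]1CC(c2cnc3c(C#N)nn([C@H](C)c4ccc(Cl)cc4Cl)c3n2)=CC[C@@H]1N1CCC[C@H]1C`, gives 34 nM, a number that lies within the scatter of the value for compound 1, so the two cannot be told apart. Compound 2, `CC1CN(c2cnc3cnn(C(C)c4ccc(Cl)cc4Cl)c3n2)CCC1N1CCCCC1`, gives 238 nM, which places it beyond the scatter as the weaker inhibitor of the three; compound 1 thus stands second highest of the three numbers, close to compound 3 and well apart from compound 2.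

Compound 4, `Cc1nn([C@H](C)c2ccc(Cl)cc2Cl)c2nc(N3CC[C@H](N4CCC[C@H]4CO)[C@H](C)C3)cnc12`, has not yet been measured. It differs from compound 1 in one place: 2-(hydroxymethyl)pyrrolidin-1-yl in place of azetidin-1-yl on a saturated ring carbon. Within the data shown here, the saturated ring carbon that carries this group is the same one that in compound 2 carries a piperidin-1-yl and in compound 3 a 2-methylpyrrolidin-1-yl, yet no single step between these measured compounds is available, since they differ in more than one place. A five-membered ring at this position in compound 3 goes with a number no worse than that of compound 1, and the change here is of that kind. The expected step from compound 1 to compound 4 is therefore a 1.3-fold lower number from compound 1 to compound 4 (0.11 log units; within the scatter), within or only slightly beyond the scatter. Compound 4 is estimated at 45 nM, with a range from 15 nM to 150 nM.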

Compound 4, half-maximal inhibitory concentration: 32 nM
Estimate against measurement, compound 4: 1.4-fold (0.15 log units) above, and the stated range covers the measured number.
By their numbers in this assay, from the lowest: compounds 4, 3 and 1 (each within the scatter of the next); then compound 2.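

Among these compounds, changing this one group gives the first direct comparison at the saturated ring carbon, where the earlier compounds differed in more than one place. In this assay, the step is a 1.8-fold lower number from compound 1 to compound 4 (0.26 log units; within the scatter), so the two compounds cannot be told apart even though 2-(hydroxymethyl)pyrrolidin-1-yl has a five-membered rather than a four-membered ring, more heavy atoms, a hydrogen-bond donor and a defined stereocentre. This position therefore accepts a substantially different amine group with no change in the number beyond the scatter, although no measurement given here explains this result.

The pair cannot separate the ring from its side chain, and a plain pyrrolidin-1-yl, a methoxymethyl or aminomethyl side chain, or a carboxylic acid in place of the hydroxymethyl would be needed to show whether the oxygen matters at all. From the compounds shown here alone, the opposite configuration at the new stereocentre also remains open, as does a direct comparison with piperidin-1-yl on the core of compound 1, since compound 2 differs from compound 1 in more than one place.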